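This account rests on a few compounds, and the source may have more. Where it says the series, first, only, none or still open, it means among the compounds named here.

Compound 2 `CCCS(=O)(=O)N1CCC(CNC(=O)c2ccc(Cl)cc2Cl)(C2CCCCN2C)CC1` gives 9.5 nM in an assay on isolated protein for inhibition of sodium- and chloride-dependent glycine transporter 1 (Homo sapiens) (a lower number here means a stronger inhibitor, a higher number a weaker inhibitor), the lowest of the two numbers here, while compound 1 `CCCS(=O)(=O)N1CCC(CNC(=O)c2ccccc2OC(F)(F)F)(C2CCCCN2C)CC1` gives 21.2 nM in this assay. Among the measured compounds shown here, the only measured step, a 2.2-fold lower number from compound 1 to compound 2 (0.35 log units; beyond the scatter), shows how far an exchange of the aryl group on the carbonyl carbon has shifted this assay so far. Compound 3 `CCCS(=O)(=O)N1CCC(CNC(=O)c2cc(F)cc(F)c2Cl)(C2CCCCN2C)CC1` carries 2-chloro-3,5-difluorophenyl in place of 2,4-dichlorophenyl on a carbonyl carbon, on a carbonyl carbon whose other neighbours are an amide-type nitrogen. Because only a 2.2-fold lower number from compound 1 to compound 2 (0.35 log units; beyond the scatter) is known, a shift no larger than that is expected for a 1.5-fold higher number from compound 2 to compound 3 (0.17 log units; within the scatter), most likely within the scatter. Compound 3 is therefore estimated at 14 nM, ranging from 6 nM to 35 nM.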

Compound 3, half-maximal inhibitory concentration: 43.1 nM
Estimate against measurement, compound 3: 3.1-fold (0.49 log units) below; measured number above the stated range.
By their numbers in this assay, from the lowest: compound 2; then compound 1; then compound 3.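

Exchanging the aryl group on the carbonyl carbon can also weaken binding in this assay: 2-chloro-3,5-difluorophenyl in place of 2,4-dichlorophenyl gives a 4.5-fold higher number from compound 2 to compound 3 (0.66 log units; beyond the scatter), and in place of 2-(trifluoromethoxy)phenyl it gives a 2.0-fold higher number from compound 1 to compound 3 (0.31 log units; beyond the scatter). Compound 3 is thus the weakest of the three, with both steps beyond the scatter, so this position tolerates change in both directions. Nothing available explains this result. The compounds shown leave open which of the halogen changes within the ring accounts for the step. They also leave open how a pyridine ring or a nitrile-bearing phenyl would behave on this carbonyl carbon.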